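This account rests on a few compounds, and the source may have more. Where it says the series, first, only, none or still open, it means among the compounds named here.

Compound 1 `COc1cc(CN(C(=O)Nc2ccc(C#N)cc2)n2cnnc2)cc(OC)c1OC` in a functional assay on MCF7 cells (Homo sapiens) for cytotoxicity, read by MTT assay, with a stated time of 48 h (a higher number here means a weaker inhibitor, a lower number a stronger inhibitor), gives > 50000 nM, a limit of the assay and not a number.
Compound 2 `COc1ccc(CN(C(=O)Nc2ccc(C#N)cc2)n2cnnc2)cc1OC` in this assay gives > 50000 nM, again a limit.
Compound 3 `O=C(Nc1ccccc1)N(Cc1ccccn1)n1cnnc1` in this assay gives > 50000 nM, again a limit.

Compound 2 thus stands at the limit, where every measured compound sits (the limit of > 50000 nM in this assay, at which 3 of the 3 values shown sit). Within the data shown here, the one change between measured compounds, a step that the two limits leave unreadable from compound 1 to compound 2, stays unreadable; both of its values are limits. Compound 4 `COc1ccc(CN(C(=O)Nc2ccc(Cl)cc2)n2cnnc2)cc1OC` differs from compound 2 by chloro in place of cyano on an aromatic carbon. Among the measured compounds shown here, no measured step bears on a change of this kind, and the measured values give no direction. Compound 4 is therefore expected to remain at or near the limit, and the expected step that the limit leaves unreadable from compound 2 to compound 4 is none beyond the scatter. Compound 4 is estimated at 60000 nM, within 15000 nM to 250000 nM.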

Compound 4, half-maximal inhibitory concentration: > 50000 nM
Compound 4 gave a limit, no number (the forecaster's own chance of this, stated with the estimate: 75%); the middle value is on the limit's open side.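

Compound 2 and compound 4 each give only a limit in this assay, so swapping cyano for chloro yields no readable step: the limit of > 50000 nM in this assay, at which 4 of the 4 values shown sit.

The compounds shown leave open which change to the shared core, if any, would give a real number in this assay.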